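From Morpholin-4-yl to Pyridin-4-yl on the Amide Nitrogen

The source may hold more compounds than are shown below. What is called first, only, known or untested is meant among the compounds shown, and "the series" means these compounds.

Three compounds have been measured in a functional assay on the whole organism for inhibition, with Rattus norvegicus as the target, read by cytopathic effect and paw edema, at a dose of 100 mg/kg by the oral route; on this read-out lower numbers stand for less inhibition and higher numbers for more inhibition at the one dose given (going by the name of the read-out):
Compound 1, `O=C(NN1CCOCC1)c1c(O)c2cccnc2n(-c2ccccc2)c1=O`, gives -26.2%.
Compound 2, `COc1ccc(NC(=O)c2c(O)c3cccnc3n(-c3ccccc3)c2=O)cc1`, gives -1.9%.
Compound 3, `O=C(Nc1cccc([N+](=O)[O-])c1)c1c(O)c2cccnc2n(-c2ccccc2)c1=O`, gives 7.4%.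

Compound 1 stands lowest of the three numbers. Its nearest neighbour is compound 2, reached by a number 24.3 percentage points higher from compound 1 to compound 2 (beyond the scatter). The furthest is compound 3, reached by a number 33.6 percentage points higher from compound 1 to compound 3 (beyond the scatter). Between the two aryl amides the gap is a number 9.3 percentage points higher from compound 2 to compound 3 (within the scatter), so those two cannot be told apart.

Compound 4, `O=C(Nc1ccncc1)c1c(O)c2cccnc2n(-c2ccccc2)c1=O`, has not yet been measured. It differs from compound 1 in one place: pyridin-4-yl in place of morpholin-4-yl on an amide-type nitrogen. Both measured steps from compound 1 exchange the same morpholin-4-yl group for a six-membered aromatic ring on the amide-type nitrogen, and both moved the number upward beyond the scatter, one modestly and one largely. The change to pyridin-4-yl is of the same kind, so an upward step is expected for compound 4, of about a number 29.2 percentage points higher from compound 1 to compound 4 (beyond the scatter). On that basis compound 4 is estimated at 3% in this assay, with a likely range from -15% to 22%.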

Compound 4, a percentage reported as inhibition, in the whole organism at one dose (the size of the read-out at that dose, not a potency): 24.3%
Estimate against measurement, compound 4: 21.3 percentage points below; measured number above the stated range.
By their numbers in this assay, from the lowest: compound 1; then compounds 2 and 3 (each within the scatter of the next); then compound 4.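

In this assay, among the compounds shown here, the change from morpholin-4-yl to pyridin-4-yl on the amide-type nitrogen gives a number 50.5 percentage points higher from compound 1 to compound 4 (beyond the scatter) and is the largest step seen at this position so far. It also shows that a six-membered aromatic ring on this nitrogen does not by itself set the number: compound 2 and compound 3 could not be told apart, yet the pyridin-4-yl group stands clear of both, with a number 26.2 percentage points higher from compound 2 to compound 4 (beyond the scatter) and a number 16.9 percentage points higher from compound 3 to compound 4 (beyond the scatter) in the same read-out. Nothing shown here explains why the pyridin-4-yl group gives the highest number of the series.

The compounds shown leave open whether the nitrogen inside the ring of compound 4 is what matters, and a plain phenyl group, pyridin-3-yl and pyridin-2-yl on the same amide-type nitrogen would be the direct comparisons. They also leave open how compound 4 behaves at other doses, as a read-out at one dose gives the size of the effect there and not a potency.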